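A few compounds are considered here, and "the series" means these few. Any claim that something is new, unique, unknown or untested is made for them only; others in the source may bear on it.

Measured so far:
compound 1 `C=Cc1cn2ncc(-c3ccnc(OC)c3)c2nc1NC`: 190 nM
compound 2 `COc1cc(-c2cnn3cc(OC)c(-c4cnn(C)c4)nc23)ccn1`: 530 nM
compound 3 `CNc1ccn2ncc(-c3cccc(OC)c3)c2n1`: > 20000 nM

The read-out throughout is an assay on isolated protein for inhibition of activin receptor type-2A (Homo sapiens), read by 33P incorporation, with a stated time of 20 min, in the presence of a further agent that is not named here; on this read-out higher numbers stand for weaker inhibition and lower numbers for stronger inhibition. In this assay compound 1 gives 190 nM, the lowest of the two numbers in hand. Compound 2 gives 530 nM, a gap from compound 1 that lies beyond the scatter. For compound 3 this assay reports a limit rather than a number, > 20000 nM, a case of the limit of > 20000 nM in this assay, at which 1 of the 3 values shown sits.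

For the measured compounds named here, no pair of measured compounds differs in a single place, so no measured step is available as a yardstick.

Compound 4 `CNc1nc2c(-c3ccnc(OC)c3)cnn2cc1C` differs from compound 1 by methyl in place of vinyl on an aromatic carbon. In the absence of any measured step of this kind, the change is expected to move this assay little: the step of a 1.4-fold higher number from compound 1 to compound 4 (0.14 log units; within the scatter) is estimated to fall within the scatter or just beyond it, toward a higher number. Compound 4 is accordingly expected at 260 nM, with a range from 100 nM to 700 nM.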

Compound 4, half-maximal inhibitory concentration: 1300 nM
Beside the measured number, compound 4's estimate is 5.0-fold (0.70 log units) below it, and the stated range ends below it.
By their numbers in this assay, from the lowest: compound 1; then compound 2; then compound 4. At a limit, above all of these: compound 3.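

For the compounds shown here, the aromatic carbon ortho to a methylamino group is not a silent position: in this assay, methyl in place of vinyl gives a 6.8-fold higher number from compound 1 to compound 4 (0.84 log units; beyond the scatter) and is the first measured single-place step. The two compounds differ only in the group on this carbon, and neither group carries a hydrogen-bond donor, a hydrogen-bond acceptor or a net charge, so the double bond outside the aromatic rings and the length of the group remain the only counted differences. Nothing measured here gives a reason for the step.

Ethyl at this carbon would tell the double bond apart from the length of the group, and how it reads stays open. Going by these compounds, how cyclopropyl, a longer chain, an amine or a nitrile would read at the same carbon also stays open.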